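The compounds below may be only part of what the source reports. "The series", "measured", "known", "first", "only" and "open" are said of these compounds alone.

Working notes on the amide series, read in an ADME assay on the whole organism (strain Sprague-Dawley) for pharmacokinetics, with Rattus norvegicus as the target, read by LC-MS, using cassette dosing, at a dose of 0.5 mg/kg by the intravenous route; on this read-out lower numbers stand for slow clearance and higher numbers for fast clearance. Compound 1 `C[C@@]1(c2cc(NC(=O)c3ncc(C#N)cc3Cl)ccc2F)C=C(CF)OC(N)=N1` gives 30.6 mL/min/kg, and compound 2 `C[C@@]1(c2cc(NC(=O)c3cnc(C(F)F)cn3)ccc2F)C=C(CF)OC(N)=N1` gives 48.1 mL/min/kg. These two values lie within the scatter of each other, so compound 2 stands level with compound 1 on the numbers available.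

Compound 3 `C[C@@]1(c2cc(NC(=O)c3ncc(OCF)nc3N)ccc2F)C=C(CF)OC(N)=N1` keeps the core of compound 2 and differs only in the group on the carbonyl carbon: 3-amino-5-(fluoromethoxy)pyrazin-2-yl in place of 5-(difluoromethyl)pyrazin-2-yl on a carbonyl carbon. In words, this is 3-amino-5-(fluoromethoxy)pyrazin-2-yl in place of 5-(difluoromethyl)pyrazin-2-yl on a carbonyl carbon.

Going by the values given here, only one measured step bears on this change, the exchange at the same place, a 1.6-fold higher number from compound 1 to compound 2 (0.20 log units; within the scatter). That single step stayed within the scatter, and it gives no direction to carry over. Among the compounds with values here, no measured compound carries the amino or the fluoromethoxy group, so the range has to stay wide. The expected step is a 1.3-fold lower number from compound 2 to compound 3 (0.13 log units; within the scatter), which is no move beyond the scatter. For compound 3 the estimated clearance is 36 mL/min/kg, with an expected range from 16 mL/min/kg to 75 mL/min/kg.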

Compound 3, clearance: 45.3 mL/min/kg
The estimate for compound 3 lay 1.3-fold (0.10 log units) below the measured number, and the stated range covers the measured number.
By their numbers in this assay, from the lowest: compounds 1, 3 and 2 (each within the scatter of the next).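

With 3-amino-5-(fluoromethoxy)pyrazin-2-yl on the carbonyl carbon, the clearance read-out in this assay shows a 1.1-fold lower number from compound 2 to compound 3 (0.03 log units; within the scatter) against 5-(difluoromethyl)pyrazin-2-yl, and a 1.5-fold higher number from compound 1 to compound 3 (0.17 log units; within the scatter) against 3-chloro-5-cyanopyridin-2-yl. Three different groups at this place now give numbers within the scatter of each other, even though the entering group brings an amino and a fluoromethoxy substituent that neither earlier group carries, so the flat picture no longer rests on a single exchange. Nothing at hand gives a reason for this result.

The amino and fluoromethoxy substituents enter together in compound 3, which leaves the contribution of each one open, and a pair with only one of them would be needed to separate the two. Also open is whether a group of another kind on the carbonyl carbon, such as a carboxylic acid or a longer alkyl chain, would step beyond the scatter, since the three groups shown here all sit on a six-membered aromatic ring and the shared core stays the same throughout.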